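The source may hold more compounds than are shown below. What is called first, only, known or untested is meant among the compounds shown, and "the series" means these compounds.

Of the compounds shown here, two of a shared core have been measured in a functional assay on MCF7 cells (Homo sapiens) for cytotoxicity, read by MTT assay, with a stated time of 24 h; a higher number here means a weaker inhibitor, a lower number a stronger inhibitor. Compound 1 `O=C(CN1CCN(c2cccc(Cl)c2)CC1)N1CCN(c2nnc(-c3ccccc3)c(-c3ccccc3)n2)CC1` gives 56300 nM. Compound 2 `COc1ccccc1N1CCN(CC(=O)N2CCN(c3nnc(-c4ccc(Cl)cc4)c(-c4ccc(Cl)cc4)n3)CC2)CC1` gives 330000 nM, which is the higher of the two numbers; the gap to compound 1, its nearest neighbour, lies beyond the scatter, so compound 2 stands as the weaker of the pair in this assay.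

Compound 3 `O=C(CN1CCN(c2ccc(Cl)cc2)CC1)N1CCN(c2nnc(-c3ccc(Cl)cc3)c(-c3ccc(Cl)cc3)n2)CC1` is not yet measured. It differs from compound 2 in one place: 4-chlorophenyl in place of 2-methoxyphenyl on an amine nitrogen in a ring. Among the compounds with values here, no pair of measured compounds differs in that one place alone, so the size of this step has to be guessed rather than read off. Compound 3 shares its substituted amine nitrogen pattern more closely with compound 1, whose value in this assay is 56300 nM, and for that reason the number for compound 3 is expected to come out somewhat lower than that of compound 2, though the change is expected to be moderate rather than large. The step from compound 2 to compound 3 is estimated as a 2.2-fold lower number from compound 2 to compound 3 (0.34 log units; beyond the scatter). Compound 3 is accordingly estimated at 150000 nM, within a range from 50000 nM to 400000 nM.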

Compound 3, half-maximal inhibitory concentration: > 803000 nM
Compound 3: no number, only a limit (the forecaster's own chance of this, stated with the estimate: 15%); middle value at least 5.3-fold (0.72 log units) away from the limit.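

In this assay, the change on an amine nitrogen in a ring, 4-chlorophenyl in place of 2-methoxyphenyl, gives an at least 2.4-fold higher number from compound 2 to compound 3 (0.38 log units; beyond the scatter). Within the data shown here, this is the first reading of a single change at this place, and it shows that the aryl group there is not a silent part of the structure, with the step running towards a weaker compound and not a stronger one. Compound 3 carries a limit and not a number, so the step has a lower bound only and its full size stays unknown: the limit of > 803000 nM in this assay, at which 1 of the 3 values shown sits.

The step swaps the methoxy group for a chlorine and also changes where the substituent sits on the phenyl ring, and the compounds shown cannot separate these two parts. They also leave open how this nitrogen would respond to an unsubstituted phenyl group, a pyridine ring or a short alkyl chain, and whether the same change would give a step of similar size on the core of compound 1, which has no chlorine on its two outer phenyl groups.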